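Ester in place of the aryl ring: compound 4

The source may report more compounds than this note shows. Statements on the series, on what has been measured and on what is new or still open speak of the compounds shown alone.

Compound 3 `CCCCCCCCc1ccc(OCC(=O)Cn2nnnc2-c2cccc(S(=O)(=O)N(C)C)c2)cc1` gives 1900 nM in an assay on microsomes from brain for inhibition of Fatty-acid amide hydrolase 1 (Rattus norvegicus), read by fluorescence and HPLC, with a stated time of 60 min (a lower number here means a stronger inhibitor, a higher number a weaker inhibitor), the highest of the three numbers in hand. Compound 1 `CCCCCCCCc1ccc(OCC(=O)Cn2nnnc2-c2ccccc2)cc1` gives 71 nM and compound 2 `CCCCCCCCc1ccc(OCC(=O)Cn2nnnc2-c2cccc(Cl)c2)cc1` gives 360 nM; the steps of a 27-fold higher number from compound 1 to compound 3 (1.43 log units; beyond the scatter) and a 5.3-fold higher number from compound 2 to compound 3 (0.72 log units; beyond the scatter) both run toward higher numbers. Compound 4 `CCCCCCCCc1ccc(OCC(=O)Cn2nnnc2C(=O)OC)cc1` carries methoxycarbonyl in place of 3-(dimethylsulfamoyl)phenyl on an aromatic carbon. Among the measured compounds shown here, the measured steps bear on this only indirectly: the whole ring goes, and no pair in hand swaps the ring for a small group. Read backwards, a 27-fold higher number from compound 1 to compound 3 (1.43 log units; beyond the scatter) shows that losing the dimethylsulfamoyl alone brings a large fall in the number, so some recovery is expected here, but the ester is no phenyl. Compound 4 is therefore expected to show a 5.4-fold lower number from compound 3 to compound 4 (0.73 log units; beyond the scatter). The estimate for compound 4 is 350 nM, with a range from 60 nM to 2000 nM.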

Compound 4, half-maximal inhibitory concentration: 1000 nM
Compound 4: middle estimate off by 2.9-fold (0.46 log units), on the low side; measured number inside the range.
By their numbers in this assay, from the lowest: compound 1; then compound 2; then compounds 4 and 3 (each within the scatter of the next).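

In this assay, the small ester methoxycarbonyl on this aromatic carbon does not match a plain phenyl (a 14-fold higher number from compound 1 to compound 4 (1.15 log units; beyond the scatter)) and also falls short of 3-chlorophenyl (a 2.8-fold higher number from compound 2 to compound 4 (0.44 log units; beyond the scatter)). Against 3-(dimethylsulfamoyl)phenyl the step lies within the scatter (a 1.9-fold lower number from compound 3 to compound 4 (0.28 log units; within the scatter)), so this ester and the most heavily substituted phenyl cannot be told apart here. No measurement at hand accounts for these steps. Still open, from the compounds shown here alone, is whether a carboxylic acid or a primary amide at this position would read differently from the ester, and whether a pyridine ring would hold the phenyl's value.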